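Bromoanilide in Place of a Dibromophenyl Ketone

The source may hold more compounds than are shown below. What is called first, only, known or untested is meant among the compounds shown, and "the series" means these compounds.

Among the measured compounds shown here, in an ADME assay on MT4 cells (Homo sapiens) for cytotoxicity, read by MTT assay (on this read-out lower numbers stand for higher toxicity in this test and higher numbers for lower toxicity in this test), compound 3 `O=C(CSc1nncnc1-c1ccccc1Cl)c1ccc(Br)cc1Br` gives 28000 nM, the lowest of the three numbers measured so far; compound 1 `COC(=O)c1ccc(NC(=O)CSc2nncnc2-c2ccccc2Cl)c(Br)c1` gives 59000 nM and compound 2 `O=C(CSc1nncnc1-c1ccccc1Cl)Nc1ccccc1` gives 127000 nM. Compound 4 `O=C(CSc1nncnc1-c1ccccc1Cl)Nc1ccccc1Br` has not yet been measured; it differs from compound 3 by (2-bromophenyl)amino in place of 2,4-dibromophenyl on a carbonyl carbon. For the measured compounds named here, the only measured step on this carbonyl carbon runs the other way: a 4.5-fold lower number from compound 2 to compound 3 (0.66 log units; beyond the scatter). Compound 4 returns to an amide, and compound 1, also an amide bearing bromine, gives a number that lies between those of compound 2 and compound 3. A modest rise is therefore expected in this assay, roughly reversing that step: compound 4 is estimated at 70000 nM, within 30000 nM to 160000 nM, a step of a 2.5-fold higher number from compound 3 to compound 4 (0.40 log units; beyond the scatter).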

Compound 4, half-maximal cytotoxic concentration: 73000 nM
Compound 4: the middle estimate sits 1.0-fold (0.02 log units) below what was measured; the measured number falls inside the stated range.
By their numbers in this assay, from the lowest: compound 3; then compounds 1, 4 and 2 (each within the scatter of the next, the first and the last beyond it).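

In this assay, (2-bromophenyl)amino in place of 2,4-dibromophenyl on a carbonyl carbon gives a 2.6-fold higher number from compound 3 to compound 4 (0.42 log units; beyond the scatter), so the ketone compound 3 is set apart from a bromoanilide as well as from the unsubstituted anilide. Bromo in place of hydrogen on an aromatic carbon gives a 1.7-fold lower number from compound 2 to compound 4 (0.24 log units; within the scatter), and hydrogen in place of methoxycarbonyl gives a 1.2-fold higher number from compound 1 to compound 4 (0.09 log units; within the scatter), so neither change separates these amides. Nothing at hand explains these steps. Open, going by these compounds, is whether a phenyl ketone without bromine would stay near compound 3, and how a carboxylic acid in place of methoxycarbonyl would read in this assay.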